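Changing the group on the carbonyl carbon of compound 2

This account rests on a few compounds, and the source may have more. Where it says the series, first, only, none or still open, it means among the compounds named here.

Compound 1 `CCNC(=O)Nc1cccc2c1CN(C)CC2c1ccccc1` gives 54 mg/kg
Compound 2 `CCOC(=O)Nc1cccc2c1CN(C)CC2c1ccccc1` gives about 4 mg/kg
Compound 3 `CCOC(=O)Nc1cccc2c1CN(C)CC2c1ccc(Cl)cc1` gives 0.6 mg/kg

In a functional assay on the whole organism for inhibition, with Mus musculus as the target (a higher number here means that more compound is needed for the effect, a lower number that less compound is needed), compound 2 gives about 4 mg/kg and sits in the middle of the three, with compound 3 lower and compound 1 higher. The unmeasured compound 4 `CC(C)NCCC(=O)Nc1cccc2c1CN(C)CC2c1ccccc1` keeps the shared core and differs from compound 2 in one place: 2-(isopropylamino)ethyl in place of ethoxy on a carbonyl carbon. In words, this is 2-(isopropylamino)ethyl in place of ethoxy on a carbonyl carbon.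

The closest guide is a 14-fold lower number from compound 1 to compound 2 (1.13 log units; beyond the scatter), a large step that also exchanges a group on a carbonyl carbon, with ethoxy in place of ethylamino. In this single pair, the compound without ethoxy has the higher number. The other step, a 6.7-fold lower number from compound 2 to compound 3 (0.82 log units; beyond the scatter), is a modest one on an aromatic carbon and says little about this change. Going by the values given here, no measured compound carries the new group, so the size remains uncertain. A rise beyond the scatter is expected, and the estimated step is a 5.0-fold higher number from compound 2 to compound 4 (0.70 log units; beyond the scatter) (smaller than the large step above). For compound 4 the expected value is 20 mg/kg within an estimated range from 5 mg/kg to 90 mg/kg (an expectation, not a measurement).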

Compound 4, dose for half-maximal effect: about 125 mg/kg
Estimate against measurement, compound 4: 6.3-fold (0.80 log units) below; the whole stated range lies below it.
By their numbers in this assay, from the lowest: compound 3; then compound 2; then compound 1; then compound 4.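

In this assay the group on the carbonyl carbon matters even more than the first pair showed: 2-(isopropylamino)ethyl in place of ethoxy gives a large rise (a 31-fold higher number from compound 2 to compound 4 (1.49 log units; beyond the scatter)). The new group also ends up higher than ethylamino, by a smaller but still real margin (a 2.3-fold higher number from compound 1 to compound 4 (0.36 log units; beyond the scatter)), so among these compounds, both groups that stand in place of ethoxy need more compound for the effect. The data shown offer no explanation for these rises.

Going by these compounds, it remains open whether a plain propyl group on the carbonyl carbon, with no amine, would give a number nearer that of compound 2 or compound 4, and what a longer chain ending in the same isopropylamino group would do. Also open, on these data alone, is whether chloro in place of hydrogen on an aromatic carbon would lower the number of compound 4 too.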